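This account rests on a few compounds, and the source may have more. Where it says the series, first, only, none or still open, it means among the compounds named here.

In a functional assay on MIA PaCa-2 cells (Homo sapiens) for antiproliferative activity, read by MTT assay, with a stated time of 72 h (on this read-out lower numbers stand for stronger inhibition and higher numbers for weaker inhibition), compound 2 (`O=C1O/C(=C\Cn2cnc3cncc(Br)c32)C(OCc2ccccc2)=C1OCc1ccccc1`) gives 22600 nM, the lowest of the three numbers in hand. Compound 3 (`O=C1NC(O)(CCn2cnc3cncc(Br)c32)C(OCc2ccccc2)=C1OCc1ccccc1`) gives 48700 nM, and compound 1 (`O=C1O/C(=C\Cn2cnc3c(F)nc(F)c(Cl)c32)C(OCc2ccccc2)=C1OCc1ccccc1`) gives 78000 nM.

Compound 4 (`O=C1O/C(=C\Cn2cnc3c(Cl)c(F)nc(F)c32)C(OCc2ccccc2)=C1OCc1ccccc1`) has not yet been measured in this assay. It departs from compound 2 by one change: a group of 12 heavy atoms (6 carbon, 3 nitrogen, 2 fluorine, 1 chlorine; one five-membered aromatic ring with 2 hetero atoms, one six-membered aromatic ring with 1 hetero atom) in place of a group of 10 heavy atoms (6 carbon, 3 nitrogen, 1 bromine; one five-membered aromatic ring with 2 hetero atoms, one six-membered aromatic ring with 1 hetero atom), on a saturated chain carbon bound to a double-bonded chain carbon. The entering group matches the group of compound 1 in its counted atoms and rings, but the two groups are not identical. Among the measured compounds shown here, the one measured step that bears on this change is a 3.5-fold lower number from compound 1 to compound 2 (0.54 log units; beyond the scatter), which is modest. Read in reverse, it points to a higher number for compound 4. For the measured compounds named here, compound 3 differs from compound 2 in the core and offers no step for this change. No measurement separates the two groups with 2 fluorine and 1 chlorine, so a rise of similar or slightly smaller size is expected, with the estimated step being a 2.7-fold higher number from compound 2 to compound 4 (0.42 log units; beyond the scatter). Compound 4 is estimated at 60000 nM, with an expected range of 28000 nM to 130000 nM.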

Compound 4, half-maximal inhibitory concentration: > 100000 nM
Compound 4 ended at the assay's limit (the forecaster's own chance of this, stated with the estimate: 15%); middle value at least 1.6-fold (0.22 log units) from the limit.
By their numbers in this assay, from the lowest: compound 2; then compounds 3 and 1 (each within the scatter of the next). At a limit, above all of these: compound 4.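

Compound 4 stands at a limit of this assay, not at a number: the limit of > 100000 nM in this assay, at which 1 of the 4 values shown sits.
On the saturated chain carbon bound to a double-bonded chain carbon, replacing the group with 1 bromine by this second group with 2 fluorine and 1 chlorine gives an at least 4.4-fold higher number from compound 2 to compound 4 (0.64 log units; beyond the scatter), so the rise seen with compound 1 is no longer confined to a single such group. Among the compounds shown here, the two groups with the same counted atoms, which no earlier compound separated, now give an at least 1.2-fold higher number from compound 1 to compound 4 (0.10 log units; that floor lies within the scatter), and no difference between them can be claimed.

Every group shown with fluorine also carries chlorine, leaving open which halogen goes with the higher numbers. Also open, on these data alone, is how the read-out responds to the same rings bearing no halogen, or bearing an amine or a carboxylic acid instead.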